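This account rests on a few compounds, and the source may have more. Where it says the series, first, only, none or still open, it means among the compounds named here.

In an ADME assay on microsomes from liver (Rattus norvegicus) for metabolic stability, read by LC-MS, using NADPH, with stated times of 5 min and 30 min, at 37 degrees C (on this read-out lower numbers stand for a shorter-lived compound and higher numbers for a longer-lived compound), compound 1 (`COC(=O)c1cccc(CC[C@H]([C@H](C)O)n2cnc3c(N)ncnc32)c1`) gives > 0.5 h as a limit of the assay and not a number. Compound 2 (`C[C@H](O)[C@@H](CCc1cccc(-c2nccs2)c1)n1cnc2c(N)ncnc21`) gives > 0.5 h and that too is a limit. Within the data shown here, neither compound has a number, and the series so far rests on the limit of > 0.5 h in this assay, at which 2 of the 2 values shown sit, alone.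

Compound 3 (`CNC(=O)c1cccc(CC[C@H]([C@H](C)O)n2cnc3c(N)ncnc32)c1`) carries methylamino in place of methoxy on a carbonyl carbon, so that methoxycarbonyl becomes methylcarbamoyl (methylamino in place of methoxy on a carbonyl carbon). Among the measured compounds shown here, the only measured step that bears on this change also removes the methoxycarbonyl, putting 1,3-thiazol-2-yl in its place on an aromatic carbon. That step is a step that the two limits leave unreadable from compound 1 to compound 2 and gives no size or direction to carry over. The step expected in this assay is a step that the limit leaves unreadable from compound 1 to compound 3 and no change beyond the scatter is assumed. A report as a limit is also expected for compound 3. As a working figure, the estimated half-life of compound 3 is 0.7 h (expected range 0.35 h to 1.5 h).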

Compound 3, half-life: > 0.5 h
Compound 3: no number, only a limit (the forecaster's own chance of this, stated with the estimate: 75%); the middle value is on the limit's open side.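

In this assay compound 3 gives > 0.5 h, which is a limit of the assay and not a number. Among these compounds, no step among compound 1, compound 2 and compound 3 can be read. The compounds shown leave open the actual half-life of each, and whether methoxycarbonyl, 1,3-thiazol-2-yl and methylcarbamoyl differ at all on this read-out: the limit of > 0.5 h in this assay, at which 3 of the 3 values shown sit.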